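This account rests on a few compounds, and the source may have more. Where it says the series, first, only, none or still open, it means among the compounds named here.

Measured so far:
- compound 1, `COC(=O)c1ccc(-c2nnn(CC(=O)C(C)Oc3ccc(Oc4ccc(F)cc4)cc3)n2)cc1`: 5.4
- compound 2, `CCCCCCCCc1ccc(OC(C)C(=O)Cn2nnc(-c3ccc(C(=O)O)cc3)n2)cc1`: 5.9

In a physicochemical assay for lipophilicity, read by HPLC, tested at 5 mM (a lower number here means a more polar compound, a higher number a more lipophilic compound), compound 2 gives 5.9, the higher of the two numbers recorded. The nearest neighbour is compound 1, which in this assay gives 5.4, a gap that lies beyond the usual scatter of this measurement.

Compound 3, `CC(Oc1ccc(Oc2ccc(F)cc2)cc1)C(=O)Cn1nnc(-c2ccc(C(=O)O)cc2)n1`, has not yet been measured. It differs from compound 2 in one place: 4-fluorophenoxy in place of octyl on an aromatic carbon. Among the compounds with values here, no measured pair with exactly this exchange is available, so the size of the step has to be guessed. Compound 1 carries the same 4-fluorophenoxy group and gives 5.4 in this assay, which suggests a downward step. The step from compound 2 to compound 3 is expected to be a number 1.00 log units lower from compound 2 to compound 3 (beyond the scatter). Compound 3 is therefore estimated at 4.9, within a range from 4.3 to 5.5.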

Compound 3, partition coefficient: 2.7
Estimate against measurement, compound 3: 2.20 log units above; the measured number lies below the stated range.
By their numbers in this assay, from the lowest: compound 3; then compound 1; then compound 2.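

In this assay, putting 4-fluorophenoxy in place of octyl on an aromatic carbon gives a number 3.20 log units lower from compound 2 to compound 3 (beyond the scatter) even though both groups hold 8 heavy atoms, so at this position the count of heavy atoms alone does not set the number. The other single change, hydrogen in place of methyl on an oxygen next to a carbonyl group, gives a number 2.70 log units lower from compound 1 to compound 3 (beyond the scatter) with 4-fluorophenoxy kept in place, so exchanging one small group can also move the number by a large step. Compound 3 therefore stands lowest of the three in this assay by a wide margin.

Nothing at hand explains either step. On these data alone, how a hexyl chain or an amine on that same aromatic carbon would read in this assay with the carboxylic acid kept in place remains open.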